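Shifting the chloroacetamide around the benzyl ring

This account rests on a few compounds, and the source may have more. Where it says the series, first, only, none or still open, it means among the compounds named here.

Compound 2 `O=C(CCl)Nc1ccc(Cn2nc(-c3ccc(Oc4ccccc4)cc3)cc2C(=O)O)cc1` gives 2500 nM in a functional assay on JeKo-1 cells (Homo sapiens) for inhibition, read by luminescence and CellTiter-Glo, with a stated time of 72 h (a lower number here means a stronger inhibitor, a higher number a weaker inhibitor), the highest of the two numbers in hand; compound 1 `CCOC(=O)c1cc(-c2ccc(Oc3ccccc3)cc2)nn1Cc1cccc(NC(=O)CCl)c1`, with an ester on the shared core and the chloroacetamide placed differently, gives 400 nM in this assay. Compound 3 `O=C(CCl)Nc1cccc(Cn2nc(-c3ccc(Oc4ccccc4)cc3)cc2C(=O)O)c1` keeps the acid of compound 2 and changes only the placement: 3-(((chloromethyl)carbonyl)amino)phenyl in place of 4-(((chloromethyl)carbonyl)amino)phenyl on a saturated chain carbon bound to an aromatic nitrogen. Going by the values given here, no single-change step is available, so the size is uncertain, but the step from compound 2 to compound 3 is expected to lower the number, a 2.1-fold lower number from compound 2 to compound 3 (0.32 log units; beyond the scatter). Compound 3 is therefore estimated at 1200 nM, within 400 nM to 4000 nM.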

Compound 3, half-maximal inhibitory concentration: 6300 nM
Beside the measured number, compound 3's estimate is 5.3-fold (0.72 log units) below it; measured number outside the range, above it.
By their numbers in this assay, from the lowest: compound 1; then compound 2; then compound 3.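

The step of a 2.5-fold higher number from compound 2 to compound 3 (0.40 log units; beyond the scatter) shows that, with the acid held fixed, 3-(((chloromethyl)carbonyl)amino)phenyl in place of 4-(((chloromethyl)carbonyl)amino)phenyl raises the number in this assay rather than lowering it. Going by these compounds alone, with that placement held fixed, hydrogen in place of ethyl on an oxygen next to a carbonyl group gives a 16-fold higher number from compound 1 to compound 3 (1.20 log units; beyond the scatter) and is the first single change on the ester, a large one. No measurement offered here explains either step.

Still open, as far as these compounds go, is how the ethyl ester behaves with 4-(((chloromethyl)carbonyl)amino)phenyl. A methyl ester or a primary amide in its place also remains an open case.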